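Aryl variation on the shared core: from compound 1 to compound 4

This account rests on a few compounds, and the source may have more. Where it says the series, first, only, none or still open, it means among the compounds named here.

Measured so far in a functional assay on HeLa cells (Homo sapiens) for inhibition, read by sulforhodamine B assay; a higher number here means a weaker inhibitor, a lower number a stronger inhibitor:
compound 1 `O=C1C(Nc2ccc(I)cc2)=CC(=O)c2c1nc1n2[C@H]2OC[C@@H](O)[C@H]2OC1` gives 4010 nM.
compound 2 `CCCc1ccc(NC2=CC(=O)c3nc4n(c3C2=O)[C@H]2OC[C@@H](O)[C@H]2OC4)cc1` gives 4990 nM.
compound 3 `O=C1C=C(Nc2ccccc2F)C(=O)c2c1nc1n2[C@H]2OC[C@@H](O)[C@H]2OC1` gives 5120 nM.

Going by the values given here, compound 1 has the lowest of the three numbers, yet the gaps from compound 1 to compound 2 and to compound 3 fall within the usual scatter of this assay, so no compound is set apart from the others.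

Compound 4 `O=C1C(Nc2cccc(F)c2)=CC(=O)c2c1nc1n2[C@H]2OC[C@@H](O)[C@H]2OC1` is not yet measured. It differs from compound 1 in one place: 3-fluorophenyl in place of 4-iodophenyl on an amine nitrogen.

Among the compounds with values here, no measured step changes a 4-iodophenyl into a 3-fluorophenyl. The nearest comparison is the exchange of the aryl group on the amine nitrogen between compound 2 and compound 3: a 1.0-fold higher number from compound 2 to compound 3 (0.01 log units; within the scatter). Across the three measured compounds, varied aryl groups on the amine nitrogen leave this assay flat within the scatter. On that basis no step beyond the scatter is expected for compound 4, and the expected step is a 1.2-fold higher number from compound 1 to compound 4 (0.08 log units; within the scatter). Compound 4 is therefore estimated at 4800 nM, with a range from 2400 nM to 9600 nM.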

Compound 4, half-maximal inhibitory concentration: > 8000 nM
Compound 4 ended at the assay's limit (the forecaster's own chance of this, stated with the estimate: 5%); middle value at least 1.6-fold (0.22 log units) away from the limit.
By their numbers in this assay, from the lowest: compounds 1, 2 and 3 (each within the scatter of the next). At a limit, above all of these: compound 4.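

In this assay compound 4 gives > 8000 nM, a limit of the assay and not a number, and it is the only compound shown that ends there: the limit of > 8000 nM in this assay, at which 1 of the 4 values shown sits. Exchanging 4-iodophenyl for 3-fluorophenyl on the amine nitrogen gives an at least 1.9-fold higher number from compound 1 to compound 4 (0.29 log units; that floor lies within the scatter), so this change has only a floor and its true size cannot be read. Compounds 1, 2 and 3 all gave numbers within the scatter of one another, whereas compound 4 shows that an aryl change at this amine nitrogen can carry a value out of the measurable range, so the flat picture no longer covers every aryl group shown, although the floor alone does not establish a step beyond the scatter.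

On these data alone, how far compound 4 lies past the limit remains open, and with it whether the change from compound 1 is a real loss or a small shift. Also open, as far as these compounds go, is whether a 4-methoxyphenyl, a benzyl group or a simple alkyl chain on the same amine nitrogen would return a number close to that of compound 1 or would also end at the limit.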